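Swapping the sulfonyl aryl group: from fluorophenyl to methoxyphenyl

The compounds below may be only part of what the source reports. "The series", "measured", "known", "first", "only" and "open" are said of these compounds alone.

Compound 1 `CC1CCN(c2c(S(=O)(=O)c3ccccc3)cnc3cc(F)ccc23)CC1`: 87%
Compound 2 `COc1cccc(S(=O)(=O)c2cnc3cc(Cl)ccc3c2N2CCC(C)CC2)c1`: 93%
Compound 3 `CC1CCN(c2c(S(=O)(=O)c3ccc(F)cc3)cnc3cc(F)ccc23)CC1`: 74.5%

Three compounds sharing one core were measured in an assay on isolated protein for displacement of a labelled ligand from metabotropic glutamate receptor 5 (Homo sapiens), with a stated time of 60 min, tested at 1 uM; on this read-out higher numbers stand for more inhibition at the one concentration tested (going by the name of the read-out) and lower numbers for less inhibition. Compound 3 stands lowest of the three: compound 1 is the nearest to it, and compound 2 the furthest, both above it beyond the scatter. Among the measured compounds shown here, the one measured step that reaches compound 3 is a number 12.5 percentage points lower from compound 1 to compound 3 (beyond the scatter), so putting a fluorine on the aryl ring attached to the sulfonyl sulfur cost a modest amount.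

Compound 4 `COc1cccc(S(=O)(=O)c2cnc3cc(F)ccc3c2N2CCC(C)CC2)c1` differs from compound 3 by 3-methoxyphenyl in place of 4-fluorophenyl on a sulfonyl sulfur. This removes the fluorine whose introduction gave a number 12.5 percentage points lower from compound 1 to compound 3 (beyond the scatter), and brings in the same methoxyphenyl group that compound 2 carries, for which compound 2 gives 93% in this assay. For the measured compounds named here, no measured step isolates the methoxy group alone, and compound 2 also differs from compound 4 in the halogen on the core, so only the two values can be compared. The expected outcome is a rise beyond the scatter, a number 13.5 percentage points higher from compound 3 to compound 4 (beyond the scatter), back toward the level of compound 1. Compound 4 is therefore estimated at 88%, within a range of 78% to 96%.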

Compound 4, a percentage reported as inhibition, at one concentration (the size of the read-out at that concentration, not a potency): 90%
Beside the measured number, compound 4's estimate is 2 percentage points below it; the range from low to high includes it.
By their numbers in this assay, from the lowest: compound 3; then compounds 1, 4 and 2 (each within the scatter of the next).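

On a sulfonyl sulfur, 3-methoxyphenyl in place of 4-fluorophenyl gives (a number 15.5 percentage points higher from compound 3 to compound 4 (beyond the scatter)) in this assay, so the fall seen with the 4-fluorophenyl group does not extend to every substituted aryl group at this position. Against the unsubstituted phenyl group, the methoxy group makes no difference that can be read (a number 3 percentage points higher from compound 1 to compound 4 (within the scatter)), and the same holds for fluoro in place of chloro on the core (a number 3 percentage points lower from compound 2 to compound 4 (within the scatter)). No evidence is available on why the 4-fluorophenyl group stands apart.

Since three of the four compounds lie within the scatter of their neighbours at the one concentration tested, these readings do not rank them by potency. From the compounds shown here alone, it also remains open how this position would respond to a more different group on the aryl ring, such as an amine or a carboxylic acid.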